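A few compounds are considered here, and "the series" means these few. Any claim that something is new, unique, unknown or untested is made for them only; others in the source may bear on it.

Compound 1, `Cc1cc(C(N)=O)nn1Cc1cc(Cl)ccc1OCc1ccccc1`, is the reference point of this set. In a physicochemical assay for lipophilicity, at pH 7.4 (a lower number here means a more polar compound, a higher number a more lipophilic compound), compound 1 gives 3.7. Compound 2, `Cc1cc(C(=O)Nc2c(F)cccc2F)nn1Cc1cc(Cl)ccc1OCc1ccccc1`, gives 3.7 in this assay, so that no change at the digits printed from compound 1 to compound 2 (within the scatter). Compound 3, `Cc1cc(C(=O)Nc2ccccn2)nn1Cc1cc(Cl)ccc1OCc1ccccc1`, is reported in this assay only as a limit, > 3.7. From this follows a number no lower from compound 1 to compound 3 (the limit leaves the size open) and likewise a number no lower from compound 2 to compound 3 (the limit leaves the size open), both left open in size because of the limit of > 3.7 in this assay, at which 1 of the 3 values shown sits. Compound 1 thus stands level with compound 2, and the remaining value is a limit.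

Compound 4, `Cc1cc(NC(=O)C2CCOC2)nn1Cc1cc(Cl)ccc1OCc1ccccc1`, differs from compound 1 in one place: ((oxolan-3-yl)carbonyl)amino in place of carbamoyl on an aromatic carbon. Within the data shown here, no measured step in this set covers such a change on the aromatic carbon; the measured steps all concern substituents on the amide-type nitrogen and, where a size could be read, stayed within the scatter. For compound 4 the expected outcome in this assay is 3.9, with a range from 3.5 to 4.3, which would mean an estimated step of a number 0.20 log units higher from compound 1 to compound 4 (within the scatter).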

Compound 4, distribution coefficient: > 3.7
Compound 4 was reported as a limit; the forecaster's own chance of this, stated with the estimate: 55%; the middle value lies beyond the limit too.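

Among these compounds, compound 4 is the first compound here in which the group on the aromatic carbon itself is exchanged, with ((oxolan-3-yl)carbonyl)amino in place of carbamoyl, whereas the earlier changes concerned only the amide-type nitrogen. In this assay compound 4 is reported only as a limit, > 3.7. This exchange gives a number no lower from compound 1 to compound 4 (the limit leaves the size open), and likewise a number no lower from compound 2 to compound 4 (the limit leaves the size open), but no step to compound 4 can be read in size because the values rest on a limit: the limit of > 3.7 in this assay, at which 2 of the 4 values shown sit.

From the compounds shown here alone, the size of this change therefore stays open, and it cannot be set against the steps on the amide-type nitrogen. Also open, going by these compounds, is what a simple amine or a carboxylic acid on the same aromatic carbon would give in this assay.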